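Swapping Bromine for Trifluoromethoxy in a Dichloroacetamide Series

The source may hold more compounds than are shown below. What is called first, only, known or untested is meant among the compounds shown, and "the series" means these compounds.

Three dichloroacetanilides have been tested in a functional assay on A549 cells (Homo sapiens) for antiproliferative activity, read by MTT assay, with a stated time of 72 h; a lower number here means a stronger inhibitor, a higher number a weaker inhibitor. Compound 1 `O=C(Nc1ccccc1Br)C(Cl)Cl` gives 37000 nM, compound 2 `O=C(Nc1ccccc1NC(=O)C(Cl)Cl)C(Cl)Cl` gives 131000 nM, and compound 3 `O=C(Nc1cccc(Br)c1)C(Cl)Cl` gives 7800 nM, the lowest number of the three and so the strongest inhibitor among them. For the measured compounds named here, the only single change measured so far, a 3.5-fold higher number from compound 1 to compound 2 (0.55 log units; beyond the scatter), replaces bromo with a second dichloroacetamide group and does not involve trifluoromethoxy. Compound 4 `O=C(Nc1cccc(OC(F)(F)F)c1)C(Cl)Cl` differs from compound 3 by trifluoromethoxy in place of bromo on an aromatic carbon. Going by the values given here, no measured step bears on this exchange, so its direction cannot be read from the data; a modest shift either way, or none beyond the scatter, is plausible. The number expected for compound 4 in this assay is therefore 10000 nM, within 3000 nM to 40000 nM. This estimate corresponds to an expected step of a 1.3-fold higher number from compound 3 to compound 4 (0.11 log units; within the scatter).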

Compound 4, half-maximal inhibitory concentration: 15100 nM
For compound 4 the middle estimate is 1.5-fold (0.18 log units) below the measured one, and the stated range covers the measured number.
By their numbers in this assay, from the lowest: compounds 3 and 4 (each within the scatter of the next); then compound 1; then compound 2.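

In this assay, trifluoromethoxy on this aromatic carbon takes the place of bromo with a 1.9-fold higher number from compound 3 to compound 4 (0.29 log units; within the scatter), so the two groups cannot be told apart here. This position therefore carries a group of 5 heavy atoms as well as one of 1 heavy atom, with no shift beyond the scatter. No measurement shown here bears on why the two groups match.

On these data alone, whether an amine or a carboxylic acid on this carbon would also stay in this range remains open. So does whether the same exchange would match at the place bromo occupies in compound 1.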